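Sultam replacement on the side chain of compound 1

This account rests on a few compounds, and the source may have more. Where it says the series, first, only, none or still open, it means among the compounds named here.

Measured so far in an assay on CHO cells for displacement of a labelled ligand from prostaglandin E2 receptor EP3 subtype (Homo sapiens), read by radioligand binding; on this read-out lower numbers stand for stronger inhibition and higher numbers for weaker inhibition:
- compound 1 `CC(C)C(c1ccc(-c2ccc3cccc(F)c3c2)[nH]c1=O)N1CCCCS1(=O)=O`: 14 nM
- compound 2 `CC(C)C(CC(N)=O)c1ccc(-c2ccc3cccc(F)c3c2)[nH]c1=O`: 5 nM

Compound 1 gives the highest of the two numbers in this assay; its nearest neighbour is compound 2, reached by a 2.8-fold lower number from compound 1 to compound 2 (0.45 log units; beyond the scatter). Compound 3 `CC(C)NC(=O)CC(c1ccc(-c2ccc3cccc(F)c3c2)[nH]c1=O)C(C)C` is not yet measured. It differs from compound 1 as follows: a group of 7 heavy atoms (5 carbon, 1 nitrogen, 1 oxygen; no ring) in place of a group of 8 heavy atoms (4 carbon, 1 nitrogen, 2 oxygen, 1 sulfur; one six-membered non-aromatic ring with 2 hetero atoms), on a saturated chain carbon bound to an aromatic carbon and a saturated chain carbon.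

Among the measured compounds shown here, the only measured step that bears on this change is the one from compound 1 to compound 2, where the same group leaves and an acyclic group without a ring enters in its place, with a modest lowering of the number beyond the scatter. The change to compound 3 likewise removes the ring-bearing group for an acyclic one, so a lower number than compound 1 is expected in this assay, of a size comparable to that step or somewhat smaller, as the entering group here is larger than in compound 2. For compound 3 the step of a 1.8-fold lower number from compound 1 to compound 3 (0.24 log units; within the scatter) is therefore expected, giving an estimated 8 nM with a range from 3 nM to 25 nM.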

Compound 3, inhibition constant: 5.8 nM
For compound 3 the middle estimate is 1.4-fold (0.14 log units) above the measured one, within the range that was stated.
By their numbers in this assay, from the lowest: compounds 2 and 3 (each within the scatter of the next); then compound 1.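

In this assay a second acyclic group, (isopropylcarbamoyl)methyl, replaces the six-membered ring group of compound 1 with a 2.4-fold lower number from compound 1 to compound 3 (0.38 log units; beyond the scatter) as the result, so the gain seen with compound 2 is not confined to the unsubstituted amide. Isopropyl in place of hydrogen on the amide-type nitrogen gives a 1.2-fold higher number from compound 2 to compound 3 (0.06 log units; within the scatter) and so no separation between the two amides, which means the amide hydrogen replaced here can carry isopropyl without a shift beyond the scatter. No measured data on these compounds offer an explanation for either step.

Still open, as far as these compounds go, is how a carboxylic acid or a primary amine would read on the same saturated chain carbon in place of the amide. Also open, from the compounds shown here alone, is whether a cyclohexyl or phenyl group on the amide-type nitrogen would hold the number at this level.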